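The compounds below may be only part of what the source reports. "The series", "measured", "known", "first", "only" and "open" are said of these compounds alone.

Three compounds have been measured in a functional assay on Ehrlich cells (Mus musculus) for antiproliferative activity, read by trypan blue exclusion, with a stated time of 2 h, tested at 25 ug/mL; a lower number here means a weaker effect, a higher number a stronger effect of the compound at the concentration tested:

Compound 1 `N#CC1=C(N)N(c2ccc(S(N)(=O)=O)cc2)C2=C(C(=O)CCC2)C1c1ccccc1`: 30%
Compound 2 `COc1ccc(C2C(C#N)=C(N)N(c3ccc(S(N)(=O)=O)cc3)C3=C2C(=O)CCC3)cc1`: 50%
Compound 3 `N#CC1=C(N)N(c2ccc(S(N)(=O)=O)cc2)C2=C(C(=O)CCC2)C1c1ccc([N+](=O)[O-])cc1`: 80%

Compound 3 stands highest of the three. Its nearest neighbour is compound 2, and the gap between them is a number 30 percentage points higher from compound 2 to compound 3 (beyond the scatter). Compound 1 lies furthest away, the step being a number 50 percentage points higher from compound 1 to compound 3 (beyond the scatter). The step of a number 20 percentage points higher from compound 1 to compound 2 (beyond the scatter) completes the set; all three steps lie beyond the scatter.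

Compound 4 `N#CC1=C(N)N(c2ccc(S(N)(=O)=O)cc2)C2=C(C(=O)CCC2)C1c1c(O)ccc2ccccc12` is not yet measured. Its change from compound 3 is 2-hydroxynaphthalen-1-yl in place of 4-nitrophenyl on a saturated ring carbon. Going by the values given here, every measured step concerns a single substituent on the aromatic ring; none replaces that ring by 2-hydroxynaphthalen-1-yl, so no step bears on the change directly. The steps that come closest are the removal of nitro, which ran as a number 50 percentage points higher from compound 1 to compound 3 (beyond the scatter) in the opposite direction, and the exchange of nitro for methoxy, which ran as a number 30 percentage points higher from compound 2 to compound 3 (beyond the scatter) in the opposite direction. Since nitro leaves, a downward step is expected, of modest to large size, with the new group itself an unknown.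

Compound 4 is therefore expected to give 45% in this assay, within a range from 20% to 75%. This estimate means a step of a number 35 percentage points lower from compound 3 to compound 4 (beyond the scatter).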

Compound 4, a percentage reported as activity, at one concentration (the size of the read-out at that concentration, not a potency): 0%
Compound 4: middle estimate off by 45 percentage points, on the high side; the measured number lies below the stated range.
By their numbers in this assay, from the lowest: compound 4; then compound 1; then compound 2; then compound 3.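

In this assay the group on the saturated ring carbon proves able to lower the read-out as well as raise it: methoxy and nitro on the phenyl ring had both lifted the number, whereas 2-hydroxynaphthalen-1-yl in place of phenyl gives a number 30 percentage points lower from compound 1 to compound 4 (beyond the scatter). The fall is larger against the substituted phenyl groups, with a number 50 percentage points lower from compound 2 to compound 4 (beyond the scatter) for 4-methoxyphenyl and a number 80 percentage points lower from compound 3 to compound 4 (beyond the scatter) for 4-nitrophenyl, which leaves compound 4 the weakest of the four, all its steps lying beyond the scatter. Nothing available accounts for this fall, and the exchange brings in a second aromatic ring and a hydroxyl together, so the data cannot assign it to either one.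

The compounds shown do not separate those two features, which a naphthalen-1-yl group without the hydroxyl or a hydroxyphenyl group would each carry alone. They also leave open whether the gain seen with 4-nitrophenyl extends to other single substituents on the phenyl ring, such as 4-cyanophenyl or 4-carboxyphenyl.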